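This account rests on a few compounds, and the source may have more. Where it says the series, first, only, none or still open, it means among the compounds named here.

Of the compounds shown here, two have been measured in a functional assay on HCT-116 cells (Homo sapiens) for antiproliferative activity, read by sulforhodamine B assay, with a stated time of 72 h; a higher number here means a weaker inhibitor, a lower number a stronger inhibitor. Compound 1 `Cn1ncc(Cl)c1-c1cc(C(=O)N[C@@H]2CN[C@H](CC(=O)NC3CC3)C[C@H]2c2ccc(Cl)c(Cl)c2)oc1Cl` gives 740 nM there, and compound 2 `COCC[C@@H]1C[C@@H](c2ccc(Cl)c(Cl)c2)[C@H](NC(=O)c2cc(-c3c(Cl)cnn3C)c(Cl)o2)CN1` gives 470 nM in this assay. The only step so far, a 1.6-fold lower number from compound 1 to compound 2 (0.20 log units; within the scatter), is small: compound 2 and compound 1 sit within the scatter of each other, so on the numbers shown neither is set apart from the other.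

Compound 3 `Cn1ncc(Cl)c1-c1cc(C(=O)N[C@@H]2CN[C@H](CC(=O)NCC(O)CO)C[C@H]2c2ccc(Cl)c(Cl)c2)oc1Cl` is the next member to be tested in this assay. The change from compound 2 is (2,3-dihydroxypropyl)carbamoyl in place of methoxymethyl on a saturated chain carbon bound to a saturated ring carbon. Going by the values given here, this bears on the one measured step, since compound 1 also carries a carbamoyl group at the same place, and the exchange of that carbamoyl for methoxymethyl, a 1.6-fold lower number from compound 1 to compound 2 (0.20 log units; within the scatter), moved the number only within the scatter. A return to a carbamoyl, now with a longer hydroxylated chain, is therefore expected to give at most a modest step in this assay, most likely back toward the number of compound 1 rather than away from it. The step expected for compound 3 is a 1.7-fold higher number from compound 2 to compound 3 (0.23 log units; within the scatter). The estimate for compound 3 in this assay is 800 nM, with a range from 300 nM to 2500 nM.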

Compound 3, half-maximal inhibitory concentration: 7090 nM
Compound 3: middle estimate off by 8.9-fold (0.95 log units), on the low side; measured number above the stated range.
By their numbers in this assay, from the lowest: compounds 2 and 1 (each within the scatter of the next); then compound 3.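

In this assay, the saturated chain carbon bound to a saturated ring carbon no longer looks tolerant of any change: the earlier exchange gave only a 1.6-fold lower number from compound 1 to compound 2 (0.20 log units; within the scatter), whereas (2,3-dihydroxypropyl)carbamoyl in place of methoxymethyl gives a 15-fold higher number from compound 2 to compound 3 (1.18 log units; beyond the scatter). The carbamoyl as such does not set the weaker number, since with that group kept, 2,3-dihydroxypropyl in place of cyclopropyl on an amide-type nitrogen still gives a 9.6-fold higher number from compound 1 to compound 3 (0.98 log units; beyond the scatter), so a change in the group on that nitrogen alone is enough for a step beyond the scatter. Nothing available on these compounds explains the loss of activity.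

The compounds shown do not separate the hydroxyl groups from the length of the chain on the amide nitrogen, so a plain propyl or a 2-methoxyethyl there would be the informative comparison with 2,3-dihydroxypropyl. As far as these compounds go, how an amine or a carboxylic acid at the end of the chain on the saturated chain carbon would read in this assay also remains open.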